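Hydrogen in Place of Phenyl on a Saturated Ring Carbon

The source may hold more compounds than are shown below. What is called first, only, known or untested is meant among the compounds shown, and "the series" means these compounds.

Compound 1 `COC[C@@H]1C[C@@H](C(=O)NCC2CCOCC2)CN(Cc2nc(-c3ccccc3)oc2C)C1`: 239 mL.min-1.g-1
Compound 2 `Cc1oc(-c2ccccc2)nc1CN1C[C@H](C(=O)NCc2cccc(N)n2)C[C@@H](c2ccccc2)C1`: > 300 mL.min-1.g-1
Compound 3 `Cc1cccc(CNC(=O)C2CCCN(Cc3nc(-c4ccccc4)oc3C)C2)n1`: 158 mL.min-1.g-1

Three compounds have been run through an in vitro ADME assay on microsomes from liver (Homo sapiens) for metabolic stability; a lower number here means slower removal, a higher number faster removal of the compound. Compound 1 gives 239 mL.min-1.g-1, and compound 3 gives 158 mL.min-1.g-1. For compound 2 the assay returns only a limit, > 300 mL.min-1.g-1, so no exact number is known for it. Compound 2 thus sits at the limit of > 300 mL.min-1.g-1 in this assay, at which 1 of the 3 values shown sits.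

Compound 4 `Cc1oc(-c2ccccc2)nc1CN1CCC[C@@H](C(=O)NCc2cccc(N)n2)C1` has not yet been measured in this assay. It differs from compound 2 in a single place: hydrogen in place of phenyl on a saturated ring carbon. Going by the values given here, no pair of measured compounds is separated by exactly this change, so there is no measured step to lean on. Compound 3 also carries hydrogen rather than phenyl on its saturated ring and gives 158 mL.min-1.g-1 in this assay, which gives a rough anchor for a core without the phenyl.

Compound 4 is therefore expected to give 170 mL.min-1.g-1 in this assay, with a likely range from 80 mL.min-1.g-1 to 300 mL.min-1.g-1. That expectation means a step of an at least 1.7-fold lower number from compound 2 to compound 4 (0.24 log units; that floor lies within the scatter), a move downward from the limit, although a limit reading for compound 4 cannot be ruled out.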

Compound 4, intrinsic clearance in microsomes: 49 mL.min-1.g-1
Beside the measured number, compound 4's estimate is 3.5-fold (0.54 log units) above it; measured number below the stated range.
By their numbers in this assay, from the lowest: compound 4; then compounds 3 and 1 (each within the scatter of the next). At a limit, above all of these: compound 2.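

In this assay, hydrogen in place of phenyl on this saturated ring carbon, two ring bonds from the ring nitrogen, gives an at least 6.1-fold lower number from compound 2 to compound 4 (0.78 log units; beyond the scatter). Going by these compounds alone, the earlier compounds held no pair separated by this one change, so this is the first direct reading of the position, and it shows that the number here depends strongly on what the ring carbon carries. The step can only be stated as a minimum, and the real gap may be wider, because compound 2 gives a limit of the assay and not an exact number: the limit of > 300 mL.min-1.g-1 in this assay, at which 1 of the 4 values shown sits.

Going by these compounds, what remains open is whether the number climbs gradually or suddenly as the group on this ring carbon changes, for instance what a methyl group, a hydroxyl group or a fluorine atom would give there in place of the phenyl. Also open, on these data alone, is whether the same swap gives a step of similar size when a group other than ((6-aminopyridin-2-yl)methyl)carbamoyl sits on the ring, since this reading rests on a single pair.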